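Replacing the aromatic group on sulfur in compound 1

The compounds below may be only part of what the source reports. "The series", "measured", "known", "first", "only" and "open" are said of these compounds alone.

Among the measured compounds shown here, in a functional assay on HeLa cells (Homo sapiens) for inhibition, read by CCK-8 assay, with a stated time of 72 h, tested at 2 uM (a higher number here means more inhibition of growth at the concentration tested, a lower number less inhibition of growth), compound 1 `COc1ccc(SCc2ccc(C(=O)Nc3ccccc3N)cc2)cc1` gives 35% of inhibition, the highest of the three numbers so far. Compound 2 `Nc1ccccc1NC(=O)c1ccc(CSc2ccc(C(F)(F)F)cn2)cc1` gives 11.5% and compound 3 `COc1ccc(SCc2ccc(C(=O)Nc3ccccc3N)cc2)cc1OC` gives 15.2% in comparison. Compound 4 `Nc1ccccc1NC(=O)c1ccc(CSCCc2ccccc2)cc1` has not been measured. Its change is phenethyl in place of 4-methoxyphenyl on a sulfur. For the measured compounds named here, no measured step makes this exact swap. The closest guide is one added methoxy (a number 19.8 percentage points lower from compound 1 to compound 3 (beyond the scatter)), a modest step beyond the scatter. Compound 2, with another group on that sulfur, also gives a lower number than compound 1. A drop of similar size is therefore expected (a number 15 percentage points lower from compound 1 to compound 4 (beyond the scatter)). In this assay compound 4 is estimated at 20%, with an expected range from 6% to 38% for repeated measurements.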

Compound 4, percent growth inhibition at one concentration: 27.7%
The estimate for compound 4 lay 7.7 percentage points below the measured number; measured number inside the range.
By their numbers in this assay, from the lowest: compounds 2 and 3 (each within the scatter of the next); then compounds 4 and 1 (each within the scatter of the next).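

Putting phenethyl in place of 4-methoxyphenyl on a sulfur leaves the number in this assay close to that of compound 1 (a number 7.3 percentage points lower from compound 1 to compound 4 (within the scatter)). For this pair, then, losing the hydrogen-bond acceptor of 4-methoxyphenyl and adding a saturated chain to the group on sulfur gives no step beyond the usual scatter. No measurement at hand offers a reason for this result.

Going by these compounds, whether a longer chain in place of phenethyl, or an amine on its ring, would keep the number in this range remains open.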